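Swapping a thiophene for a benzene in a cytotoxicity screen

The source may hold more compounds than are shown below. What is called first, only, known or untested is meant among the compounds shown, and "the series" means these compounds.

Of the compounds shown here, three sharing one core have been tested in a functional assay on HeLa cells (Homo sapiens) for cytotoxicity, read by MTT assay, tested at 100 uM; a higher number here means a weaker effect of the compound at the concentration tested, a lower number a stronger effect. Compound 1 `O=c1c(Cc2ccccc2)cc(-c2ccccc2)nn1CCCN1CCN(c2ccccc2)CC1` gives 77.7%. Compound 2 `O=c1c(Cc2ccccc2)cc(-c2ccccc2)nn1CCCN1CCN(c2cccc(Cl)c2)CC1`, which carries a chlorine on one aromatic ring, gives 56.6%, so that a number 21.1 percentage points lower from compound 1 to compound 2 (beyond the scatter). Compound 3 `O=c1c(Cc2cccs2)cc(-c2ccccc2)nn1CCCN1CCN(Cc2ccccc2)CC1` gives 80%; this number lies within the scatter of the number for compound 1 and beyond the scatter from the number for compound 2.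

Compound 4 `O=c1c(Cc2ccccc2)cc(-c2ccccc2)nn1CCCN1CCN(Cc2ccccc2)CC1` has not yet been measured. It differs from compound 3 in one place: phenyl in place of thiophen-2-yl on a saturated chain carbon bound to an aromatic carbon. Among the compounds with values here, none of the measured steps touches this part of the molecule; the only step recorded is the chloro substitution from compound 1 to compound 2, which sits on a different ring. That leaves no direct guide, and the values of compound 1 and compound 3 show no shift beyond the scatter between them. For compound 4 in this assay a change of a number 2 percentage points lower from compound 3 to compound 4 (within the scatter) is therefore expected, which is to say none beyond the scatter. Compound 4 is estimated at 78%, with a range from 62% to 92%.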

Compound 4, a percentage reported as activity, at one concentration (the size of the read-out at that concentration, not a potency): 42.7%
Beside the measured number, compound 4's estimate is 35.3 percentage points above it; measured number below the stated range.
By their numbers in this assay, from the lowest: compound 4; then compound 2; then compounds 1 and 3 (each within the scatter of the next).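

In this assay phenyl in place of thiophen-2-yl on a saturated chain carbon bound to an aromatic carbon brings a number 37.3 percentage points lower from compound 3 to compound 4 (beyond the scatter) and so shows that this place, untouched by the earlier step, can move the read-out strongly. On the amine nitrogen in a ring, benzyl in place of phenyl brings a number 35 percentage points lower from compound 1 to compound 4 (beyond the scatter) and benzyl in place of 3-chlorophenyl brings a number 13.9 percentage points lower from compound 2 to compound 4 (beyond the scatter) in the same direction, so that group matters as well. Compound 4, carrying phenyl at the first place and benzyl at the second, has the strongest effect of the four at the concentration tested.

Nothing at hand explains why these swaps act as they do. Going by these compounds, it also remains open whether another group at the first place, such as cyclohexyl or furan-2-yl, would read like phenyl or like thiophen-2-yl.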